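Replacing the cyclohexylamino urea end with a fused aromatic group

The source may report more compounds than this note shows. Statements on the series, on what has been measured and on what is new or still open speak of the compounds shown alone.

Three measured compounds share one core and differ only at the amide-type nitrogen of the urea. In an ADME assay on WI-38 cells (Homo sapiens), read by MTT assay, with a stated time of 72 h (a lower number here means a stronger inhibitor, a higher number a weaker inhibitor), compound 1 `COc1cc(NC(C)CCCNC(=O)NCc2ccncc2)c2ncccc2c1` gives 10000 nM. Compound 2 `COc1cc(NC(C)CCCNC(=O)NC2CCCCC2)c2ncccc2c1` reaches only the upper limit of this assay, > 100000 nM, which is a limit and not a number (the limit of > 100000 nM in this assay, at which 1 of the 3 values shown sits). Compound 3 `COc1cc(NC(C)CCCNC(=O)N(C2CCCCC2)C2CCCCC2)c2ncccc2c1` gives 18000 nM. Compound 2 therefore stands as the weakest of the three: the step of an at least 10-fold higher number from compound 1 to compound 2 (1.00 log units; beyond the scatter), and the step of an at least 5.5-fold lower number from compound 2 to compound 3 (0.74 log units; beyond the scatter), both lie beyond the scatter and both lead away from compound 2.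

Compound 4 `COc1cc(NC(C)CCCNC(=O)n2nnc3ccccc32)c2ncccc2c1` differs from compound 2 by a group of 9 heavy atoms (6 carbon, 3 nitrogen; one five-membered aromatic ring with 3 hetero atoms, one six-membered aromatic ring of carbon only) in place of a group of 7 heavy atoms (6 carbon, 1 nitrogen; one six-membered non-aromatic ring of carbon only), on a carbonyl carbon. Both measured changes at this part of the molecule moved the number from the limit to a measurable value, so a lowering is expected here as well, of a size comparable to those steps: the expected step is an at least 5.0-fold lower number from compound 2 to compound 4 (0.69 log units; beyond the scatter). Compound 4 is estimated at 20000 nM, between 5000 nM and 100000 nM.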

Compound 4, half-maximal inhibitory concentration: > 100000 nM
Compound 4: no number, only a limit; the forecaster's own chance of this, stated with the estimate: 25%; at least 5.0-fold (0.69 log units) between middle value and limit.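

For the compounds shown here, compound 4 stands at a limit of this assay, > 100000 nM, which is a limit and not a number, and it shares that limit with compound 2: the limit of > 100000 nM in this assay, at which 2 of the 4 values shown sit. The step between these two compounds cannot be read, so this is the first change at this carbonyl carbon that leaves the value unmeasurable, and any difference between cyclohexylamino and the fused aromatic group stays hidden. The comparison with the (pyridin-4-yl)methyl urea can be read and shows an at least 10-fold higher number from compound 1 to compound 4 (1.00 log units; beyond the scatter), so an aromatic ring at this end does not by itself give a measurable value.

Going by these compounds, how far compound 2 and compound 4 actually lie from each other remains open. A benzylamino group on the same carbonyl carbon would test whether the ring nitrogen of compound 1 matters for its value.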